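The compounds below may be only part of what the source reports. "The series", "measured", "known", "first", "only" and "open" are said of these compounds alone.

Of the compounds shown here, three that share one core have so far been tested in a functional assay on the whole organism with Mus musculus as the target, in the maximal electroshock model, at a dose of 50 mg/kg by the oral route; a lower number here means less inhibition, a higher number more inhibition at the dose given (going by the name of the read-out). Compound 1 `CCN1CCN(CCCCOc2ccccc2/C=C/c2ccccc2)CC1` gives 33.3% there. Compound 2 `CCCOC1CCCN(CCCCOc2ccccc2/C=C/c2ccccc2)C1` gives 0% in this assay, and compound 3 `OCC1CCCN(CCCCOc2ccccc2/C=C/c2ccccc2)C1` gives 12.5%. Among these three numbers compound 3 holds the second highest place: its nearest neighbour is compound 2, with a number 12.5 percentage points higher from compound 2 to compound 3 (beyond the scatter), and its furthest is compound 1, with a number 20.8 percentage points lower from compound 1 to compound 3 (beyond the scatter).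

Compound 4 `COC(=O)C1CCCN(CCCCOc2ccccc2/C=C/c2ccccc2)C1` has not yet been measured in this assay. It differs from compound 3 in one place, (methoxycarbonyl in place of hydroxymethyl on a saturated ring carbon). Going by the values given here, of the two measured steps, the one that bears most on this change is the one in which the group on that same saturated ring carbon was exchanged, propoxy for hydroxymethyl; it moved the read-out by a modest amount, as a number 12.5 percentage points higher from compound 2 to compound 3 (beyond the scatter) shows. The other step exchanged the whole ring and so speaks less directly to a change of one group on the ring carbon. Since the exchange of one group on that carbon gave only a modest step last time, a similar size of step, downward, is expected for compound 4, namely a number 4.5 percentage points lower from compound 3 to compound 4 (within the scatter). The estimate for compound 4 in this assay is therefore 8%, with a likely range from 0% to 25%.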

Compound 4, a percentage reported as inhibition, in the whole organism at one dose (the size of the read-out at that dose, not a potency): 0%
Estimate against measurement, compound 4: 8 percentage points above; measured number inside the range.
By their numbers in this assay, from the lowest: compounds 2 and 4 (each within the scatter of the next); then compound 3; then compound 1.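

Going by these compounds alone, exchanging hydroxymethyl for methoxycarbonyl on this saturated ring carbon in this assay gives a number 12.5 percentage points lower from compound 3 to compound 4 (beyond the scatter) and so shows that propoxy is not the only group that stands a clear step under hydroxymethyl at this place. Methoxycarbonyl and propoxy cannot be told apart in this read-out, with no change at the digits printed from compound 2 to compound 4 (within the scatter) as their step, so of the three groups shown on this carbon only hydroxymethyl gives a number above zero at the dose used. Nothing measured here explains why the exchange lowers the number.

Going by these compounds, whether an amine or a carboxylic acid on this carbon would stand nearer to hydroxymethyl or to methoxycarbonyl stays open, as does whether a longer chain such as hydroxyethyl would keep the number of compound 3. Also open, on these data alone, is whether the hydrogen-bond donor matters at all, since its loss in compound 4, where the count goes from 1 to 0, comes together with a larger group, so a pair that changes only one of these would be needed to separate them.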